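From methyl to propyl on the shared core

A few compounds are considered here, and "the series" means these few. Any claim that something is new, unique, unknown or untested is made for them only; others in the source may bear on it.

Compound 1 `CC(C)c1ccc(OC(C)(Cc2ccc(C(F)(F)F)cc2)C(=O)O)cc1`: < 5 mg/kg
Compound 2 `Cc1ccc(CC(C)(Oc2ccc(C(C)C)cc2)C(=O)O)cc1`: < 1 mg/kg

Both compounds were tested in a functional assay on the whole organism for inhibition, with Rattus norvegicus as the target; on this read-out lower numbers stand for an effect already at smaller amounts and higher numbers for an effect only at larger amounts of compound. Compound 2 gives < 1 mg/kg, and this is a limit and not a number. Compound 1 gives < 5 mg/kg, which is also a limit. Neither compound therefore has an exact position on this read-out.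

Compound 3 `CCCc1ccc(CC(C)(Oc2ccc(C(C)C)cc2)C(=O)O)cc1` is reached from compound 2 by ethyl in place of hydrogen on a saturated chain carbon bound to an aromatic carbon. In words, this is ethyl in place of hydrogen on a saturated chain carbon bound to an aromatic carbon, and the same difference reads methyl to propyl.

Going by the values given here, only one measured step bears on this change, and it bears on it weakly. It is a step that the two limits leave unreadable from compound 1 to compound 2, with methyl in place of trifluoromethyl on an aromatic carbon. That step offers no size to carry over and points in no direction, so no shift in this assay beyond the usual scatter can be predicted with any confidence.

The expected change is a step that the limit leaves unreadable from compound 2 to compound 3, and it is a cautious estimate.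

For compound 3 the estimated value is 0.8 mg/kg, with an expected range from 0.2 mg/kg to 3 mg/kg.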

Compound 3, dose for half-maximal effect: 0.5 mg/kg
The estimate for compound 3 lay 1.6-fold (0.20 log units) above the measured number; the range from low to high includes it.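

In this assay compound 3 gives 0.5 mg/kg. Compound 2 gives < 1 mg/kg, which is a limit. Compound 1 gives < 5 mg/kg, which is also a limit. The steps to compound 3 from compound 2 and from compound 1 therefore cannot be read. As far as these compounds go, whether propyl, methyl and trifluoromethyl differ at all on this read-out, and by how much, stays open.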